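Replacing the sulfamoylamino group on the saturated ring

The compounds below may be only part of what the source reports. "The series", "measured", "known", "first", "only" and "open" are said of these compounds alone.

Of the compounds shown here, three have been measured in an assay on CHO-K1 cells for displacement of a labelled ligand from melanin-concentrating hormone receptor 1 (Homo sapiens), read by scintillation proximity assay, with a stated time of 2 h; a lower number here means a stronger inhibitor, a higher number a weaker inhibitor. Compound 1 `Cc1nc(N2CCC(NS(=O)(=O)N(C)C)CC2)nc2ccc(NC(=O)/C=C/c3ccc(OC(F)(F)F)cc3)cc12` gives 105 nM, compound 2 `COc1ccc(/C=C/C(=O)Nc2ccc3nc(N4CCC(O)(C5CC5)CC4)nc(C)c3c2)cc1` gives 116 nM, and compound 3 `Cc1ccc(/C=C/C(=O)Nc2ccc3nc(N4CCC(O)(C5CC5)CC4)nc(C)c3c2)cc1` gives 344 nM. Within the data shown here, the only single-point step among them, a 3.0-fold higher number from compound 2 to compound 3 (0.47 log units; beyond the scatter), concerns the aromatic substituent at the far end of the molecule. Compound 1 has the lowest number of the three, but compound 2 sits within the usual scatter of it, so no order between those two can be drawn; only compound 3 is clearly set apart from compound 1.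

Compound 4 `Cc1nc(N2CCC(N3CCCC3=O)CC2)nc2ccc(NC(=O)/C=C/c3ccc(OC(F)(F)F)cc3)cc12` is not yet measured. It differs from compound 1 in a single place: 2-oxopyrrolidin-1-yl in place of (dimethylsulfamoyl)amino on a saturated ring carbon. Among the measured compounds shown here, no measured pair changes the group on the saturated ring carbon; the methoxy-to-methyl step between compound 2 and compound 3 lies at a different place and gives no guide here. The data therefore offer nothing that points to a shift in either direction for this change, and the expectation is a step of a 1.2-fold higher number from compound 1 to compound 4 (0.09 log units; within the scatter) that stays within the scatter. Compound 4 is estimated at 130 nM, with a range from 45 nM to 400 nM.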

Compound 4, half-maximal inhibitory concentration: 11 nM
For compound 4 the middle estimate is 12-fold (1.07 log units) above the measured one, and the stated range ends above it.
By their numbers in this assay, from the lowest: compound 4; then compounds 1 and 2 (each within the scatter of the next); then compound 3.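

Among these compounds, the first measured change at this place shows that the group on the saturated ring carbon matters in this assay: swapping (dimethylsulfamoyl)amino for 2-oxopyrrolidin-1-yl gives a 9.5-fold lower number from compound 1 to compound 4 (0.98 log units; beyond the scatter). Among the compounds shown here, the earlier compounds could not show this, as their only single-place step lay on the aromatic substituent. The change replaces an open group holding 1 hydrogen-bond donor and 2 hydrogen-bond acceptors with a five-membered non-aromatic ring holding 0 hydrogen-bond donors and 1 hydrogen-bond acceptor, and no measurement available here connects any of these differences to the step.

With only one change at this place, the compounds shown cannot separate the contributions of the ring, the carbonyl, the loss of the sulfur-containing group and the loss of the donor; an open-chain acetamide, a six-membered piperidin-2-one or a plain amine on the same ring carbon would help to tell these apart. Also open, from the compounds shown here alone, is whether a step of this size would hold if the trifluoromethoxy group of compound 4 were replaced by methoxy.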